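The source may report more compounds than this note shows. Statements on the series, on what has been measured and on what is new or still open speak of the compounds shown alone.

Measured in a functional assay on NCI-H460 cells (Homo sapiens) for inhibition, read by CCK-8 assay, with a stated time of 72 h, tested at 1 uM; on this read-out lower numbers stand for less inhibition of growth and higher numbers for more inhibition of growth at the one concentration tested:
- compound 1 `CN(C)C(=O)c1cc2cnc(Nc3ccc(NC(=O)C4(C(=O)Nc5ccc(F)cc5)CC4)cc3)nc2n1C1CCCC1`: 79.9%
- compound 2 `CN(C)C(=O)c1cc2cnc(Nc3ccc(NC(=O)C4(C(=O)Nc5cccc(F)c5)CC4)cc3)nc2n1C1CCCC1`: 45.1%
- compound 3 `CN(C)C(=O)c1cc2cnc(Nc3ccc(NC(=O)C4(C(=O)Nc5cccc(Cl)c5)CC4)cc3)nc2n1C1CCCC1`: 44%

Compound 1 stands highest of the three. Compound 4 `CN(C)C(=O)c1cc2cnc(Nc3ccc(NC(=O)C4(C(=O)Nc5ccc(F)cc5)CC4)cc3F)nc2n1C1CCCC1` departs from it by fluoro in place of hydrogen on an aromatic carbon, which is fluoro in place of hydrogen on an aromatic carbon. All three measured steps concern a different part of the molecule. Two are large, a number 34.8 percentage points lower from compound 1 to compound 2 (beyond the scatter) and a number 35.9 percentage points lower from compound 1 to compound 3 (beyond the scatter), while a number 1.1 percentage points lower from compound 2 to compound 3 (within the scatter) lies within the scatter. They show that this assay can respond sharply to a small change, but they give no direction for this one. No step beyond the scatter is therefore expected, though a lower number seems likelier than a higher one. The estimated change is a number 6.9 percentage points lower from compound 1 to compound 4 (within the scatter). For compound 4 the expected value is 73%, with an estimated range of 48% to 90%.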

Compound 4, percent growth inhibition at one concentration: 11.9%
Beside the measured number, compound 4's estimate is 61.1 percentage points above it; measured number outside the range, below it.
By their numbers in this assay, from the lowest: compound 4; then compounds 3 and 2 (each within the scatter of the next); then compound 1.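

In this assay, a fluoro in place of hydrogen on an aromatic carbon, ortho to a large group and meta to a large group, gives a number 68 percentage points lower from compound 1 to compound 4 (beyond the scatter), so this single added heavy atom is enough for a large change. The earlier steps shown here showed sensitivity only at the aryl group on the amide-type nitrogen, whereas this one shows that a different part of the molecule also responds sharply. No measurement available here accounts for the change.

From the compounds shown here alone, whether a methyl or methoxy group at this position would give a similar number remains open. So does whether fluoro would have the same effect on the other carbons of this ring.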